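The compounds below may be only part of what the source reports. "The series", "measured", "known", "first", "only" and "open" are said of these compounds alone.

Measured so far:
compound 1 `COc1ccc2nc(C)cc(OCC(=O)Nc3cccc(C)c3)c2c1`, 4.83
compound 2 `COc1ccc2nc(C)cc(OCC(=O)Nc3ccc(Cl)c(OC)c3)c2c1`, 5.09

In a physicochemical assay for lipophilicity, read by HPLC, in phosphate buffer, measured as chromatographic lipophilicity, at pH 7.4 (a lower number here means a more polar compound, a higher number a more lipophilic compound), compound 2 stands at the higher of the two numbers, but its nearest neighbour, compound 1, differs from it only by a number 0.26 log units higher from compound 1 to compound 2 (within the scatter), so the two cannot be told apart. Compound 3 `COc1ccc2nc(C)cc(OCC(=O)Nc3ccccn3)c2c1` differs from compound 2 by pyridin-2-yl in place of 4-chloro-3-methoxyphenyl on an amide-type nitrogen. Among the measured compounds shown here, the only measured step, a number 0.26 log units higher from compound 1 to compound 2 (within the scatter), exchanged one substituent pattern on a carbon-only ring for another and stayed within the scatter; it does not cover the loss of the chlorine and the methoxy together with the arrival of a ring holding one hetero atom. That change is expected to give an estimated step of a number 1.49 log units lower from compound 2 to compound 3 (beyond the scatter), a downward step expected to exceed the scatter. Compound 3 is therefore estimated at 3.6, with a plausible span from 3 to 4.2.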

Compound 3, distribution coefficient: 3.49
For compound 3 the middle estimate is 0.11 log units above the measured one; measured number inside the range.
By their numbers in this assay, from the lowest: compound 3; then compounds 1 and 2 (each within the scatter of the next).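

In this assay the group on the amide-type nitrogen proved able to move the number a long way: pyridin-2-yl gives a number 1.60 log units lower from compound 2 to compound 3 (beyond the scatter) and a number 1.34 log units lower from compound 1 to compound 3 (beyond the scatter) for the two earlier compounds. Among the compounds shown here, the earlier pair, both with a ring of carbon only, could not be told apart, so this is the first change at this position that lies beyond the scatter, and it does so from either starting point. Nothing available gives a reason for the drop.

Each step swaps the ring and removes its substituents together, so how much belongs to the ring nitrogen and how much to the lost substituents stays unresolved. From the compounds shown here alone, an unsubstituted phenyl would separate the two, while a pyridin-2-yl carrying a chlorine, or an amine or carboxylic acid at this place, remains unexplored here.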